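Inverting the chain stereocentre of a tetrabrominated alcohol

This account rests on a few compounds, and the source may have more. Where it says the series, first, only, none or still open, it means among the compounds named here.

Measured so far:
- Compound 1, `OC(CCn1nc2c(Br)c(Br)c(Br)c(Br)c2n1)c1cccc(Br)c1`, gives 118% in a functional assay on CCRF-CEM cells (Homo sapiens) for antiproliferative activity, read by MTT assay, with a stated time of 48 h, tested at 12.5 uM; on this read-out higher numbers stand for a weaker effect at the one concentration tested and lower numbers for a stronger effect.
- Compound 2, `COc1cccc(C(O)CCn2nc3c(Br)c(Br)c(Br)c(Br)c3n2)c1`, gives 96% in this assay.
- Compound 3, `C[C@@H](O)CCn1nc2c(Br)c(Br)c(Br)c(Br)c2n1`, gives 94% in this assay.

The three share one core and differ at the alcohol-bearing end of the chain. Among the compounds with values here, the single step between compounds differing in one place is the one from compound 1 to compound 2, a number 22 percentage points lower from compound 1 to compound 2 (beyond the scatter), a change at an aromatic carbon of the pendant ring. Compound 3 sits at the low end of the three numbers: its value lies within the scatter of that of compound 2 and beyond the scatter from that of compound 1.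

Compound 4, `C[C@H](O)CCn1nc2c(Br)c(Br)c(Br)c(Br)c2n1`, is the next compound to be read. Against compound 3 the difference is the two compounds have the same atoms and bonds and differ only in configuration as drawn: 1 of 1 stereo elements differ; a stereocentre at a saturated chain carbon is drawn R in compound 3 and S in compound 4. Within the data shown here, no measured step concerns a change of configuration, and the only step in hand, from compound 1 to compound 2, swaps a group on a ring rather than inverting a centre, so it gives no guide to direction or size here. Among the measured compounds shown here, with no precedent to the contrary, the step from compound 3 to compound 4 is expected to be a number 2 percentage points higher from compound 3 to compound 4 (within the scatter), that is, nothing beyond the scatter. Compound 4 is therefore estimated at 96%, in the range 82% to 112%.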

Compound 4, a percentage reported as activity, at one concentration (the size of the read-out at that concentration, not a potency): 92%
Beside the measured number, compound 4's estimate is 4 percentage points above it, and the stated range covers the measured number.
By their numbers in this assay, from the lowest: compounds 4, 3 and 2 (each within the scatter of the next); then compound 1.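

Inverting the stereocentre at the saturated chain carbon gives a number 2 percentage points lower from compound 3 to compound 4 (within the scatter) in this assay, the first measured change of configuration in the series, and at the one concentration tested it does not separate the two forms. The earlier step, a number 22 percentage points lower from compound 1 to compound 2 (beyond the scatter), showed a read-out that responds to a ring substituent swap; the drawn configuration at this chain carbon, by contrast, leaves no difference that can be told from scatter in this pair. The comparison is a clean one, since no other structural feature can account for the outcome: the fact that compounds 3 and 4 differ only in the configuration as drawn

As far as these compounds go, whether the same inversion would stay as silent in compounds carrying the pendant ring, such as compound 1 and compound 2, or at a concentration other than the one used here, remains open. So does the question of how the chain end would read with an amine or a carboxylic acid in place of the alcohol, or with a longer chain between the core and the stereocentre.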